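This account rests on a few compounds, and the source may have more. Where it says the series, first, only, none or still open, it means among the compounds named here.

Measured in an ADME assay (liver) for metabolic stability, with Liver microsome (Rattus norvegicus) as the target, using microsomes and NADPH, with a stated time of 30 min, tested at 1 uM; a higher number here means faster removal of the compound, a lower number slower removal:
- Compound 1 `Nc1ccc(S(=O)(=O)N2CCN(c3ncc(C(O)(C(F)(F)F)C(F)(F)F)cc3-c3ccoc3)CC2)cn1`: 57 mL.min-1.g-1
- Compound 2 `COc1cncc(-c2cc(C(O)(C(F)(F)F)C(F)(F)F)cnc2N2CCN(S(=O)(=O)c3ccc(N)nc3)CC2)c1`: 58 mL.min-1.g-1

Going by the values given here, compound 2 cannot be told apart from its only measured neighbour. Among the compounds with values here, the one measured step is a 1.0-fold higher number from compound 1 to compound 2 (0.01 log units; within the scatter), for 5-methoxypyridin-3-yl in place of furan-3-yl on an aromatic carbon.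

Compound 3 `Nc1ccc(S(=O)(=O)N2CCN(c3ncc(C(O)(C(F)(F)F)C(F)(F)F)cc3-c3ccc4sccc4c3)CC2)cn1` carries 1-benzothiophen-5-yl in place of 5-methoxypyridin-3-yl on that same aromatic carbon (1-benzothiophen-5-yl in place of 5-methoxypyridin-3-yl on an aromatic carbon). Within the data shown here, the measured step is the only guide here, and it is a thin one: a single swap, involving neither sulfur nor a second ring. The expectation therefore starts from compound 2 at 58 mL.min-1.g-1 and leans only slightly upward, with a wide margin. The expected step is a 1.3-fold higher number from compound 2 to compound 3 (0.11 log units; within the scatter), and the data cannot firmly fix its direction. For compound 3 the estimated value is 75 mL.min-1.g-1, with an expected range of 40 mL.min-1.g-1 to 140 mL.min-1.g-1.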

Compound 3, intrinsic clearance in microsomes: 487 mL.min-1.g-1
Estimate against measurement, compound 3: 6.5-fold (0.81 log units) below; the whole stated range lies below it.
By their numbers in this assay, from the lowest: compounds 1 and 2 (each within the scatter of the next); then compound 3.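

In this assay, this aromatic carbon proves sensitive to what it carries: the swap between furan-3-yl and 5-methoxypyridin-3-yl changed nothing beyond the scatter, yet 1-benzothiophen-5-yl gives an 8.4-fold higher number from compound 2 to compound 3 (0.92 log units; beyond the scatter) and an 8.5-fold higher number from compound 1 to compound 3 (0.93 log units; beyond the scatter) in the same read-out. Both earlier groups therefore read alike, while this one, with its fused five- and six-membered aromatic rings, stands clearly apart with much faster removal. Nothing available explains why this group behaves so differently.

The change brings in sulfur and a second ring at once, and the compounds shown cannot separate the two. Also open, on these data alone, is how a plain phenyl ring, or a benzofuran with oxygen in place of the sulfur, would read at this position.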